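The compounds below may be only part of what the source reports. "The series", "measured", "known", "first", "only" and "open" are said of these compounds alone.

Compound 1 `O=C(O)c1cc(-c2ccc(-c3ccc(Cl)cc3Cl)cc2)n(Cc2cccnc2)n1` is one of three compounds examined in an assay on isolated protein for inhibition of methionine--tRNA ligase, cytoplasmic (Homo sapiens); a lower number here means a stronger inhibitor, a higher number a weaker inhibitor. For compound 1 the assay reports only a limit, > 100000 nM, which is a limit of the assay rather than a number (the limit of > 100000 nM in this assay, at which 1 of the 3 values shown sits). Compound 2 `O=C(O)c1cc(-c2ccc(-c3ccccc3)cc2)n(-c2ccc(Cl)cc2Cl)n1` carries the dichlorophenyl group on the ring nitrogen instead and gives 44300 nM. Compound 3 `O=C(O)c1cccc(-c2ccc(-c3cc(C(=O)O)nn3-c3ccc(Cl)cc3Cl)cc2)c1` adds a carboxy group to the distal ring of compound 2; compound 3 gives 40900 nM, and the step of a 1.1-fold lower number from compound 2 to compound 3 (0.03 log units; within the scatter) is a carboxy in place of hydrogen on an aromatic carbon and changes nothing beyond the scatter. Compound 4 `O=C(O)c1cc(-c2ccc(-c3ccc(Cl)cc3Cl)cc2)n(CCO)n1` is so far unmeasured. It differs from compound 1 by hydroxymethyl in place of pyridin-3-yl on a saturated chain carbon bound to an aromatic nitrogen. Going by the values given here, no measured step touches this position, so none of the measured steps bears directly on it; the only step measured, from compound 2 to compound 3, was small. The expectation for compound 4 in this assay is therefore a step of a number no higher from compound 1 to compound 4 (the limit leaves the size open), with a fair chance that only a limit is returned again. Compound 4 is thus estimated at 100000 nM, within 30000 nM to 300000 nM.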

Compound 4, half-maximal inhibitory concentration: > 100000 nM
Compound 4 ended at the assay's limit; the forecaster's own chance of this, stated with the estimate: 60%; the middle value sits exactly at the limit.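

In this assay, compound 1 and compound 4 both end at a limit of the assay rather than a number, so no step between them can be read: the limit of > 100000 nM in this assay, at which 2 of the 4 values shown sit.

The compounds shown leave open whether replacing (pyridin-3-yl)methyl with 2-hydroxyethyl changes inhibition at all.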